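The source may report more compounds than this note shows. Statements on the series, on what has been measured and on what is new or still open speak of the compounds shown alone.

Compound 2 `CC(O)CNc1nc(-c2ccccc2)nc2c1nnn2Cc1ccccc1Cl` gives 32000000 nM in an assay on isolated protein for binding affinity to adenosine receptor A1 (Bos taurus); a higher number here means a weaker inhibitor, a lower number a stronger inhibitor. Among the three measured compounds it stands second highest: compound 1 `Clc1ccccc1Cn1nnc2c(NC3CCC3)nc(-c3ccccc3)nc21` gives 24000000 nM, and a 1.3-fold higher number from compound 1 to compound 2 (0.12 log units; within the scatter) lies within the scatter, while compound 3 `CCNc1nc(-c2ccccc2)nc2c1nnn2Cc1ccccc1Cl` gives 463000000 nM, and a 14-fold higher number from compound 2 to compound 3 (1.16 log units; beyond the scatter). Compound 4 `CC(O)CNc1nc(-c2ccccc2)nc2c1nnn2Cc1ccccc1F` differs from compound 2 by fluoro in place of chloro on an aromatic carbon. Going by the values given here, no measured step touches this part of the molecule; the measured steps, a 19-fold higher number from compound 1 to compound 3 (1.29 log units; beyond the scatter) among them, all change the group on the nitrogen on the aromatic ring, and the ring bearing the chloro is the same in compounds 1, 2 and 3. No step beyond the scatter is therefore expected in this assay. Compound 4 is estimated at 32000000 nM, in the range 10000000 nM to 100000000 nM, so that no change at the digits printed from compound 2 to compound 4 (within the scatter) is expected.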

Compound 4, inhibition constant: 4800000 nM
Beside the measured number, compound 4's estimate is 6.7-fold (0.82 log units) above it, outside the stated range (below it).
By their numbers in this assay, from the lowest: compound 4; then compounds 1 and 2 (each within the scatter of the next); then compound 3.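

In this assay, fluoro in place of chloro on an aromatic carbon gives a 6.7-fold lower number from compound 2 to compound 4 (0.82 log units; beyond the scatter) and so lies beyond the scatter. Going by these compounds alone, the earlier steps all changed the group on the nitrogen and kept the 2-chlorobenzyl group, so this is the first sign that the number also responds to a single-atom exchange on this ring. Nothing measured here explains the step.

The compounds shown leave open what hydrogen, methyl or methoxy would give at this place. They also leave open whether 2-fluorobenzyl in place of 2-chlorobenzyl gives a similar step with cyclobutyl or ethyl on the nitrogen.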